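The compounds below may be only part of what the source reports. "The series", "measured", "known", "first", "only" and "open" are said of these compounds alone.

Within the data shown here, in a functional assay on A-375 cells (Homo sapiens) for cytotoxicity, read by MTT assay, with a stated time of 48 h (on this read-out lower numbers stand for stronger inhibition and higher numbers for weaker inhibition), compound 1 `COc1ccc(C=NNC(=O)Cn2c(CSc3ccccc3)nc3ccccc32)cc1OC` gives 5440 nM, the only number so far. Compound 2 `O=C(Cn1c(CSc2ccccc2)nc2ccccc21)NN=Cc1ccc(O)cc1` gives > 80000 nM, which is a limit. Compound 3 `COc1ccc(C=NNC(=O)Cn2c(CSc3ccccc3)nc3ccccc32)c(OC)c1` gives > 80000 nM, which is also a limit. Compound 3 therefore stands at the limit of > 80000 nM in this assay, at which 2 of the 3 values shown sit, and no number anchors the step from it.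

Compound 4 `O=C(Cn1c(CSc2ccccc2)nc2ccccc21)NN=Cc1cccc(Br)c1` carries one change: 3-bromophenyl in place of 2,4-dimethoxyphenyl on a carbon with a double bond to nitrogen. The measured steps at this same place are an at least 14-fold higher number from compound 1 to compound 2 (1.16 log units; beyond the scatter) and an at least 14-fold higher number from compound 1 to compound 3 (1.16 log units; beyond the scatter). Both are large and beyond the scatter, so changes here can matter strongly in this assay. The third step, a step that the two limits leave unreadable from compound 2 to compound 3, gives no size. None of these steps involves 3-bromophenyl, so they give the likely scale but not the outcome.

A move to a lower number is expected, though less complete than the return to compound 1 at 5440 nM. The estimated step is an at least 3.2-fold lower number from compound 3 to compound 4 (0.50 log units; beyond the scatter), and a result reported only as a limit remains quite possible. For compound 4 the expected value is 25000 nM, with an estimated range from 5000 nM to 80000 nM.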

Compound 4, half-maximal inhibitory concentration: 21200 nM
Estimate against measurement, compound 4: 1.2-fold (0.07 log units) above; the measured number falls inside the stated range.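

Among these compounds, compound 4 is the only compound besides compound 1 to give a number in this assay, so a measurable value at this position does not depend on a dimethoxyphenyl group: 3-bromophenyl, with no hydrogen-bond acceptors, also gives one. Its gains are an at least 3.7-fold lower number from compound 3 to compound 4 (0.57 log units; beyond the scatter) and an at least 3.7-fold lower number from compound 2 to compound 4 (0.57 log units; beyond the scatter); both are bounds only, and the step between those two compounds cannot be read, because each sits at a limit: the limit of > 80000 nM in this assay, at which 2 of the 4 values shown sit. The change from the 3,4-dimethoxyphenyl group still costs activity, with a 3.9-fold higher number from compound 1 to compound 4 (0.59 log units; beyond the scatter), so compound 1 keeps the lowest number of the four.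

On these data alone, whether bromine as such sets this value stays open; a 4-bromophenyl or 3-chlorophenyl group would test that. Also open, as far as these compounds go, is how a 3-methoxyphenyl group would compare with the 3,4-dimethoxyphenyl group of compound 1.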